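This account rests on a few compounds, and the source may have more. Where it says the series, first, only, none or still open, it means among the compounds named here.

Compound 1, `COc1cc(C(=O)/C=C/c2cc(-c3cc(OC)c(OC)c(OC)c3)n3nc(-c4ccccc4)cc3n2)cc(OC)c1OC`, gives 20500 nM in a functional assay on A549 cells (Homo sapiens) for antiproliferative activity, read by MTT assay, with a stated time of 24 h; on this read-out higher numbers stand for weaker inhibition and lower numbers for stronger inhibition. Compound 2, `COc1cc(-c2cc(/C=C/C(=O)c3ccccc3)nc3cc(-c4ccccc4)nn23)cc(OC)c1OC`, gives 18200 nM in this assay. Compound 3, `COc1cc(-c2cc(/C=C/C(=O)c3ccc(C)c(C)c3)nc3cc(-c4ccccc4)nn23)cc(OC)c1OC`, gives 10600 nM in this assay.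

Compound 3 stands at one end of these three numbers, but its separation from the others stays inside the scatter: a 1.7-fold lower number from compound 2 to compound 3 (0.23 log units; within the scatter) and a 1.9-fold lower number from compound 1 to compound 3 (0.29 log units; within the scatter). Compound 4, `COc1cc(-c2cc(/C=C/C(=O)c3ccc(Cl)cc3)nc3cc(-c4ccccc4)nn23)cc(OC)c1OC`, differs from compound 3 by 4-chlorophenyl in place of 3,4-dimethylphenyl on a carbonyl carbon. All three measured steps change the aryl on the carbonyl carbon and none leaves the scatter, a 1.1-fold lower number from compound 1 to compound 2 (0.05 log units; within the scatter) included. On that basis no step beyond the scatter is expected in this assay for compound 4, and the step expected is a 1.1-fold higher number from compound 3 to compound 4 (0.05 log units; within the scatter). Compound 4 is therefore estimated at 12000 nM, within a range from 5000 nM to 30000 nM.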

Compound 4, half-maximal inhibitory concentration: 15500 nM
Beside the measured number, compound 4's estimate is 1.3-fold (0.11 log units) below it; measured number inside the range.
By their numbers in this assay, from the lowest: compounds 3, 4, 2 and 1 (each within the scatter of the next).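

In this assay, a halogen on the aryl at this carbonyl carbon also stays within the scatter: chloro in place of hydrogen on an aromatic carbon gives a small step (a 1.2-fold lower number from compound 2 to compound 4 (0.07 log units; within the scatter)). Neither 4-chlorophenyl in place of 3,4-dimethylphenyl (a 1.5-fold higher number from compound 3 to compound 4 (0.17 log units; within the scatter)) nor 4-chlorophenyl in place of 3,4,5-trimethoxyphenyl (a 1.3-fold lower number from compound 1 to compound 4 (0.12 log units; within the scatter)) leaves it either, so all four aryl groups remain indistinguishable here. Nothing available bears on why these numbers lie so close together.

The compounds shown leave open whether an amine or a carboxylic acid on this aryl would produce a step beyond the scatter.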